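The source may report more compounds than this note shows. Statements on the series, on what has been measured and on what is new or still open speak of the compounds shown alone.

Measured compounds:

Compound 1 `CN(C)c1ccc(C2CC(c3cc4ccccc4o3)=NN2C(=O)c2ccncc2)cc1`: in an ADME assay on Vero cells (Chlorocebus sabaeus) for cytotoxicity, read by MTT assay, with a stated time of 72 h (a lower number here means a stronger inhibitor, a higher number a weaker inhibitor), compound 1 gives a limit of > 210000 nM.
Compound 2 `O=C(O)c1ccccc1C1CC(c2cc3ccccc3o2)=NN1C(=O)c1ccncc1`: in this assay compound 2 gives a limit of > 170000 nM.
Compound 3 `O=C(c1ccncc1)N1N=C(c2cc3ccccc3o2)CC1c1ccc(Cl)cc1`: in this assay compound 3 gives a limit of > 220000 nM.

None of the three values is a number; each marks the highest concentration tested, as the lines (the limit of > 170000 nM in this assay, at which 1 of the 3 values shown sits), the limit of > 210000 nM in this assay, at which 1 of the 3 values shown sits, and the limit of > 220000 nM in this assay, at which 1 of the 3 values shown sits, show. Compound 3 therefore stands at a limit, alongside two further limits, and nothing separates it from compound 1 or compound 2 on these data.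

Compound 4 `COc1ccc(C2CC(c3cc4ccccc4o3)=NN2C(=O)c2ccncc2)cc1` differs from compound 3 in one place: methoxy in place of chloro on an aromatic carbon. The measured steps that touch compound 3 are a step that the two limits leave unreadable from compound 1 to compound 3 and a step that the two limits leave unreadable from compound 2 to compound 3; a third step, a step that the two limits leave unreadable from compound 1 to compound 2, is unreadable for the same reason. Three changes of the group on the saturated ring carbon left every value at a limit, so no step beyond the scatter is expected in this assay here either; the step that the limit leaves unreadable from compound 3 to compound 4 is an estimate of no change. Compound 4 is expected to give about 250000 nM, within 100000 nM to 1000000 nM, most likely again as a limit.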

Compound 4, half-maximal inhibitory concentration: > 200000 nM
Compound 4: only a limit was reported; the forecaster's own chance of this, stated with the estimate: 85%; the middle value lies beyond the limit too.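

In this assay compound 4 gives > 200000 nM, which is a limit and not a number. Among the compounds shown here, compound 1, compound 2 and compound 3 also give only limits, so no step to compound 4 can be read. The compounds shown leave open where the true value of each compound lies and whether these group changes make any difference in this assay.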